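An Isopropyl for Two Fluorines on a Weak Chalcone

The source may hold more compounds than are shown below. What is called first, only, known or untested is meant among the compounds shown, and "the series" means these compounds.

compound 1 `O=C(COc1ccc(C(=O)/C=C/c2ccc(F)c(F)c2)cc1)N[C@H]1CCOC1=O`: > 64000 nM
compound 2 `O=C1OCC[C@@H]1NC(=S)SCCOc1ccccc1`: 53800 nM
compound 3 `O=C1OCC[C@@H]1NC(=S)SCCOc1ccccc1Cc1ccccc1`: 32300 nM

In a functional assay on MGC-803 cells (Homo sapiens) for antiproliferative activity, read by MTT assay, with a stated time of 72 h (on this read-out lower numbers stand for stronger inhibition and higher numbers for weaker inhibition), compound 1 gives only a limit, > 64000 nM, so its true number is not known. Going by the values given here, compound 2 and compound 3 share a different core, and the single measured step between them, a 1.7-fold lower number from compound 2 to compound 3 (0.22 log units; within the scatter), does not touch the part of compound 1 that changes here. Compound 4 `CC(C)c1ccc(/C=C/C(=O)c2ccc(OCC(=O)N[C@H]3CCOC3=O)cc2)cc1` differs from compound 1 by 4-isopropylphenyl in place of 3,4-difluorophenyl on a double-bonded chain carbon bound to a double-bonded chain carbon. Among the compounds with values here, no measured step covers that exchange, and compound 1 sits at the limit given by the limit of > 64000 nM in this assay, at which 1 of the 3 values shown sits, so no direction can be read from the data. Compound 4 is therefore expected near that same limit, at 60000 nM with a range from 20000 nM to 150000 nM. The resulting step, an at least 1.0-fold lower number from compound 1 to compound 4 (0.02 log units; that floor lies within the scatter), is an estimate of no change beyond the scatter.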

Compound 4, half-maximal inhibitory concentration: 16800 nM
The estimate for compound 4 lay 3.6-fold (0.55 log units) above the measured number, and the stated range ends above it.
By their numbers in this assay, from the lowest: compounds 4, 3 and 2 (each within the scatter of the next, the first and the last beyond it). At a limit, above all of these: compound 1.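

With 4-isopropylphenyl in place of 3,4-difluorophenyl on a double-bonded chain carbon bound to a double-bonded chain carbon, the number in this assay moves beyond the scatter: an at least 3.8-fold lower number from compound 1 to compound 4 (0.58 log units; beyond the scatter). Going by these compounds alone, this shows that the aromatic group at this place can change the read-out, which no earlier step could show. The true size of the step stays unknown because the value of compound 1 is a limit, not a number: the limit of > 64000 nM in this assay, at which 1 of the 4 values shown sits.

From the compounds shown here alone, how a tert-butyl group or a dimethylamino group in place of the isopropyl would read remains open. Also open, going by these compounds, is whether the same exchange would change the number on another core.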